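This account rests on a few compounds, and the source may have more. Where it says the series, first, only, none or still open, it means among the compounds named here.

Compound 1 `CCN(CC)C(=O)Oc1c(-c2ccccc2C)c(C)nc2cc(OC)c(Cl)cc12`: (< 1000 nM), a limit and not a number
Compound 2 `COc1cc2nc(C)c(-c3ccccc3C)c(OC(=O)N3CCCC3)c2cc1Cl`: (2900 nM)

Among the compounds with values here, in a physicochemical assay for solubility, at pH 7.4 (on this read-out higher numbers stand for higher solubility and lower numbers for lower solubility), compound 2 gives (2900 nM), the only true number so far. Compound 3 `CCOC(=O)Oc1c(-c2ccccc2C)c(C)nc2cc(OC)c(Cl)cc12` carries ethoxy in place of pyrrolidin-1-yl on a carbonyl carbon. Within the data shown here, the one measured step that bears on this change also alters the group on that carbonyl carbon (an at least 2.9-fold higher number from compound 1 to compound 2 (0.46 log units; beyond the scatter)). It lies beyond the scatter, and the compound without pyrrolidin-1-yl has the lower reading. It is a single step with a limit at one end, and it swaps one nitrogen group for another, so it guides the direction only loosely. A modest fall in this assay is expected (a 1.9-fold lower number from compound 2 to compound 3 (0.29 log units; within the scatter)). The estimate for compound 3 is (1500 nM), with an expected range from (500 nM) to (4000 nM).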

Compound 3, solubility: < 1000 nM
Compound 3 was reported as a limit; the forecaster's own chance of this, stated with the estimate: 35%; middle value at least 1.5-fold (0.17 log units) away from the limit.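

In this assay, the earlier step had only exchanged one nitrogen group for another on this carbonyl carbon, whereas ethoxy in place of pyrrolidin-1-yl removes the nitrogen from that place and gives an at least 2.9-fold lower number from compound 2 to compound 3 (0.46 log units; beyond the scatter). Among the three compounds, the only one with a true number is therefore compound 2, the one carrying pyrrolidin-1-yl, while neither diethylamino nor ethoxy gives a reading that rises clear of the limit. The reading of compound 3 is a limit and not a number, and it is the same limit as that of compound 1: the limit of < 1000 nM in this assay, at which 2 of the 3 values shown sit.

The step from compound 1 to compound 3 cannot be read, so diethylamino and ethoxy stay unordered. Going by these compounds, whether another nitrogen ring on this carbonyl carbon, such as piperidin-1-yl or morpholin-4-yl, would match compound 2 remains open.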